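Methoxy for Fluoro Repeated on a Second Core

This account rests on a few compounds, and the source may have more. Where it says the series, first, only, none or still open, it means among the compounds named here.

Three compounds were measured in a functional assay on HL-60 cells (Homo sapiens) for cytotoxicity, read by MTT assay, with a stated time of 48 h; on this read-out higher numbers stand for weaker inhibition and lower numbers for stronger inhibition. Compound 1 `Cc1ccc(Cn2c(/C=C3\SC(=S)N(CC(=O)O)C3=O)nc3cc(F)ccc32)cc1` gives 1170 nM, and compound 2 `Cc1ccc(Cn2c(/C=C3\SC(=S)N(CC(=O)O)C3=O)nc3ccc(F)cc32)cc1` gives 1690 nM; the difference between the two cores is not broken down here. Compound 3 `COc1ccc2c(c1)nc(/C=C1\SC(=S)N(CC(=O)O)C1=O)n2Cc1ccc(C)cc1` gives 770 nM in this assay. The change from compound 1 to compound 3, (methoxy in place of fluoro on an aromatic carbon), made a 1.5-fold lower number from compound 1 to compound 3 (0.18 log units; within the scatter). Compound 4 `COc1ccc2nc(/C=C3\SC(=S)N(CC(=O)O)C3=O)n(Cc3ccc(C)cc3)c2c1` has not yet been measured; it differs from compound 2 by the same change, (methoxy in place of fluoro on an aromatic carbon), at a place described in the same words. Among the measured compounds shown here, the step from compound 2 to compound 4 is expected to be about as large as the earlier one, a 1.5-fold lower number from compound 2 to compound 4 (0.17 log units; within the scatter), because the only guide is the single observed step of a 1.5-fold lower number from compound 1 to compound 3 (0.18 log units; within the scatter), which itself lies within the scatter. Compound 4 is therefore estimated at 1150 nM, likely between 500 nM and 2600 nM.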

Compound 4, half-maximal inhibitory concentration: 1920 nM
Beside the measured number, compound 4's estimate is 1.7-fold (0.22 log units) below it; measured number inside the range.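

In this assay, methoxy in place of fluoro on the second core gave a 1.1-fold higher number from compound 2 to compound 4 (0.06 log units; within the scatter). Set beside the step on the first core, the two steps do not differ: the same change on two cores in this assay, a 1.5-fold lower number (0.18 log units; within the scatter) from compound 1 to compound 3 and a 1.1-fold higher number (0.06 log units; within the scatter) from compound 2 to compound 4, 1.7-fold (0.24 log units) apart, within the scatter of two such steps. This agrees with the change carrying over between these two cores, but only in the sense that neither step stands out from the scatter; two such small steps show neither that the change has a real effect in this series nor that the cores respond to it differently.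

The compounds shown leave open whether any other group at this place would move the number beyond the scatter on either core. An amine or a nitrile in place of the fluoro or methoxy would be one such test.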